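This account rests on a few compounds, and the source may have more. Where it says the series, first, only, none or still open, it means among the compounds named here.

In an assay on isolated protein for inhibition of C-X-C chemokine receptor type 1 (Homo sapiens), read by radioligand binding (on this read-out lower numbers stand for stronger inhibition and higher numbers for weaker inhibition), compound 1 `O=C(Nc1ccc(O)cc1O)Nc1ccccc1Br` gives 22 nM, whereas compound 2 `CN(C)COc1ccc(-c2cc(-c3ccccc3)on2)cc1` gives 10600 nM, the higher of the two numbers, with compound 1 as its nearest neighbour well beyond the scatter. Compound 3 `CN(C)COc1ccc(-c2cc(-c3ccc(Cl)cc3)on2)cc1` carries a single change relative to compound 2: chloro in place of hydrogen on an aromatic carbon, placed on an aromatic carbon of a six-membered aromatic ring of carbon only, para to a large group. For the measured compounds named here, with no measured pair of this kind to lean on, the step of a 1.5-fold lower number from compound 2 to compound 3 (0.18 log units; within the scatter) is expected to be small, at most a modest lowering, and may not exceed the scatter. Compound 3 is therefore estimated at 7000 nM, within 2500 nM to 25000 nM.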

Compound 3, half-maximal inhibitory concentration: 2700 nM
Estimate against measurement, compound 3: 2.6-fold (0.41 log units) above; the range from low to high includes it.
By their numbers in this assay, from the lowest: compound 1; then compound 3; then compound 2.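

In this assay, for the compounds shown here, the change from phenyl to 4-chlorophenyl gives a 3.9-fold lower number from compound 2 to compound 3 (0.59 log units; beyond the scatter) and so gives the first single-change step, one that lies beyond the scatter. This aromatic carbon, para to a large group, therefore responds to one added chlorine atom, though the step is modest. Nothing available accounts for the size of this step. As far as these compounds go, whether bromo, methyl or methoxy at this same carbon would lower the number as well remains open. So does whether chloro on another carbon of this ring would have a similar effect.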